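Notes on the phenyl to 4-methoxyphenyl step

A few compounds are considered here, and "the series" means these few. Any claim that something is new, unique, unknown or untested is made for them only; others in the source may bear on it.

Values so far in a functional assay on PC-12 cells (Rattus norvegicus) for cytotoxicity, read by MTT assay, with a stated time of 24 h (a higher number here means that more compound is needed for the effect, a lower number that less compound is needed), are:
compound 1 `Cc1ccc(C#N)c(N2CCN(CC#CCOC(=O)c3sc4ncnc(N5CCCCC5)c4c3C)CC2)c1` gives 38.2 ug/mL
compound 2 `Cc1c(C(=O)OCC#CCN2CCN(c3ccc(Br)cc3C#N)CC2)sc2ncnc(N3CCCCC3)c12` gives 40.9 ug/mL
compound 3 `Cc1c(-c2nnc(-c3ccccc3)o2)sc2ncnc(N3CCCCC3)c12` gives 22.1 ug/mL

Compound 3 lies within the scatter of both compound 1 and compound 2, so the three values carry no order. Compound 4 `COc1ccc(-c2nnc(-c3sc4ncnc(N5CCCCC5)c4c3C)o2)cc1` has methoxy in place of hydrogen on an aromatic carbon, para to a large group, counted as methoxy in place of hydrogen on an aromatic carbon in full. Within the data shown here, the one measured step of a 1.1-fold higher number from compound 1 to compound 2 (0.03 log units; within the scatter) swaps a different group, 4-bromo-2-cyanophenyl for 2-cyano-5-methylphenyl, and stays within the scatter. Among the measured compounds shown here, no measured step adds methoxy, so no shift beyond the scatter is expected in this assay here. The estimate starts from compound 3 at 22.1 ug/mL with no real shift assumed. The expected step of a 1.0-fold higher number from compound 3 to compound 4 (0.02 log units; within the scatter) stays within the scatter. For compound 4 the expected value is 23 ug/mL within an estimated range of 12 ug/mL to 42 ug/mL overall.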

Compound 4, half-maximal effective concentration: 20.1 ug/mL
Beside the measured number, compound 4's estimate is 1.1-fold (0.06 log units) above it, within the range that was stated.
By their numbers in this assay, from the lowest: compounds 4, 3, 1 and 2 (each within the scatter of the next, the first and the last beyond it).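

In this assay the phenyl of compound 3 now has a measured change at the carbon para to a large group: methoxy in place of hydrogen gives a 1.1-fold lower number from compound 3 to compound 4 (0.04 log units; within the scatter) and so leaves the number unmoved beyond the scatter. Among these compounds, the earlier step changed a different group on the amine nitrogen of another side chain, so this is the first reading for this position on the phenyl. Nothing available bears on the reason for this result.

Still open, as far as these compounds go, is whether an amine or a carboxylic acid at this carbon would shift the number beyond the scatter. A longer chain such as butoxy leaves the same question open.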